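Indole series: fluorinated substituent swap on compound 2

This account rests on a few compounds, and the source may have more. Where it says the series, first, only, none or still open, it means among the compounds named here.

Two members of this series have been measured in an assay for inhibition of Group 10 secretory phospholipase A2 (Homo sapiens), with stated times of 20 min and 60 min; a lower number here means a stronger inhibitor, a higher number a weaker inhibitor. Compound 1 `CS(=O)(=O)NC(=O)CCc1cccc(-n2c(C(N)=O)cc3ccccc32)c1` gives 4800 nM. Compound 2 `NC(=O)c1cc2ccc(OC(F)F)cc2n1-c1cccc(CCC(=O)O)c1` gives 68 nM, the lower of the two numbers; its gap to compound 1 lies well beyond the usual scatter, so compound 2 stands as the stronger inhibitor of the pair. Among the measured compounds shown here, no step between measured compounds that differ in a single place is available, so the next change has to be judged from the structures alone.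

Compound 3 `NC(=O)c1cc2ccc(C(F)(F)F)cc2n1-c1cccc(CCC(=O)O)c1` differs from compound 2 in one place: trifluoromethyl in place of difluoromethoxy on an aromatic carbon. Both groups are small and fluorinated and sit at the same place on the shared core. In this assay the change is expected to give only a small step, a 1.3-fold higher number from compound 2 to compound 3 (0.12 log units; within the scatter), not beyond the scatter in either direction. Compound 3 is therefore estimated at 90 nM, with a range from 30 nM to 270 nM.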

Compound 3, half-maximal inhibitory concentration: 43 nM
Compound 3: the middle estimate sits 2.1-fold (0.32 log units) above what was measured, within the range that was stated.
By their numbers in this assay, from the lowest: compounds 3 and 2 (each within the scatter of the next); then compound 1.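

The swap gives the series its first comparison at a single place: trifluoromethyl in place of difluoromethoxy on an aromatic carbon gives a 1.6-fold lower number from compound 2 to compound 3 (0.20 log units; within the scatter) in this assay. This place on the shared core therefore accepts either fluorinated group without a step beyond the scatter. That holds although the oxygen and the hydrogen-bond acceptor counted for difluoromethoxy leave, a third fluorine enters and the heavy-atom count stays the same; no measurement is available to explain the result.

Among the compounds shown here, still open is how far this tolerance extends at this place, as the pair covers only two fluorinated groups of equal heavy-atom count. A plain hydrogen, a methoxy group, a nitrile or an amine could show whether the fluorine atoms matter here, and a longer alkoxy chain could show how much size the place accepts.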